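The source may report more compounds than this note shows. Statements on the series, on what has been measured and on what is new or still open speak of the compounds shown alone.

Measured in a functional assay on MCF-A cells (Homo sapiens) for cytotoxicity; on this read-out lower numbers stand for stronger inhibition of growth and higher numbers for weaker inhibition of growth
compound 1 `COc1ccc(C2=C(c3ccc(SC)cc3)CC3CCCN3C2=O)cc1C` gives 400 nM
compound 2 `CSc1ccc(C2=C(c3ccc(C)c(C)c3)C(=O)N3CCCC3C2)cc1` gives 800 nM
compound 3 `CSc1ccc(C2=C(c3ccc(OCC4CO4)cc3)C(=O)N3CCCC3C2)cc1` gives 10000 nM

Among these three, compound 3 at 10000 nM has the highest number in this assay, with compound 2 at 800 nM and compound 1 at 400 nM. The gap from compound 3 to each of those two lies beyond the scatter. Compound 4 `CSc1ccc(C2=C(c3ccc(SC)cc3)C(=O)N3CCCC3C2)cc1` has not yet been measured. It differs from compound 3 in one place: methylsulfanyl in place of (oxiran-2-yl)methoxy on an aromatic carbon. Put in words, methylsulfanyl stands in place of (oxiran-2-yl)methoxy on an aromatic carbon.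

Going by the values given here, only one measured step links two compounds by a single exchange: a 2.0-fold higher number from compound 1 to compound 2 (0.30 log units; within the scatter). That step, methyl in place of methoxy on an aromatic carbon, stays within the scatter, but it is a different exchange and only bears on this one indirectly. Among the compounds with values here, no measured step removes (oxiran-2-yl)methoxy, so the expectation rests mainly on the values. Within the data shown here, compound 3, the only measured compound carrying that group, stands apart, while compound 1 at 400 nM and compound 2 at 800 nM stay close together. Compound 4 is therefore expected to fall near those two, which would be a move to a lower number, beyond the scatter. The expected step runs a 17-fold lower number from compound 3 to compound 4 (1.22 log units; beyond the scatter). The estimate for compound 4 is 600 nM, with an expected range from 200 nM to 2500 nM.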

Compound 4, concentration for 50% growth inhibition: 8000 nM
Estimate against measurement, compound 4: 13-fold (1.12 log units) below; the measured number lies above the stated range.
By their numbers in this assay, from the lowest: compounds 1 and 2 (each within the scatter of the next); then compounds 4 and 3 (each within the scatter of the next).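

In this assay, methylsulfanyl on the aromatic carbon para to a large group, with no ring and fewer heavy atoms, stands within the scatter of (oxiran-2-yl)methoxy at that place (a 1.3-fold lower number from compound 3 to compound 4 (0.10 log units; within the scatter)), so the high number of compound 3 does not require the three-membered ring. Going by these compounds alone, the earlier compounds could not show this, as compound 3 was the only one with a high number and the only one carrying that ring. What separates the high and low numbers among these compounds is instead the whole aryl group on the double-bonded ring carbon, since 4-(methylsulfanyl)phenyl raises the number both in place of 3,4-dimethylphenyl (a 10-fold higher number from compound 2 to compound 4 (1.00 log units; beyond the scatter)) and in place of 4-methoxy-3-methylphenyl (a 20-fold higher number from compound 1 to compound 4 (1.30 log units; beyond the scatter)), and nothing available accounts for these steps.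

On these data alone, both low-number groups carry a methyl group that the groups of compound 3 and compound 4 lack, but whether that methyl group matters on its own remains open. Also open, as far as these compounds go, is what an amine or a carboxylic acid would give on the aromatic carbon where compound 3 and compound 4 differ.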